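A few compounds are considered here, and "the series" means these few. Any claim that something is new, unique, unknown or untested is made for them only; others in the source may bear on it.

Values in an ADME assay on BAEC cells (Bos taurus) for cytotoxicity, read by MTT assay, with a stated time of 2 days; on this read-out higher numbers stand for weaker inhibition and lower numbers for stronger inhibition:
- compound 1 `COc1c(Br)cc(C=O)c(O)c1Br`: 806000 nM
- compound 2 `COc1c(Br)cc(CO)c(O)c1Br`: > 16000 nM (a limit of the assay, not a number)
- compound 3 `COC1=C(Br)C(=O)[C@]2(C=C1)CO2`: 11000 nM

Not yet measured: compound 4 `COc1c(Br)cc(C=O)c(OC(C)=O)c1Br`.

In this assay compound 1 holds the higher of the two actual numbers, beyond the scatter from compound 3. The change to compound 4 puts acetyl in place of hydrogen on an oxygen on an aromatic ring. For the measured compounds named here, the only measured step, a step that the limit leaves unreadable from compound 1 to compound 2, lies elsewhere on the core and gives no size, so the expectation rests on the spread of values alone. With compound 1 at 806000 nM and compound 3 at 11000 nM, a move towards lower numbers is expected, with low confidence. The expected change is a 6.7-fold lower number from compound 1 to compound 4 (0.83 log units; beyond the scatter). For compound 4 the estimate is 120000 nM, with an expected range of 15000 nM to 800000 nM.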

Compound 4, half-maximal inhibitory concentration: 23000 nM
Beside the measured number, compound 4's estimate is 5.2-fold (0.72 log units) above it; low and high end bracket the measured number.
By their numbers in this assay, from the lowest: compound 3; then compound 4; then compound 1.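

In this assay, for the compounds shown here, acetoxy in place of hydroxy on the aromatic ring gives a 35-fold lower number from compound 1 to compound 4 (1.54 log units; beyond the scatter), the first step with a readable size. This oxygen is therefore the only place on the shared core shown to respond, with the formyl group left unchanged. Nothing shown gives a cause for this step.

Still open, from the compounds shown here alone, is whether the step depends on the acetyl group itself or only on the loss of the hydrogen. A methyl ether or a longer acyl chain such as butanoyl on the same oxygen would separate the two.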